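The source may hold more compounds than are shown below. What is called first, only, known or untested is meant among the compounds shown, and "the series" means these compounds.

Compound 1, `CC(C)C(=O)OCOC(=O)C1=C(S[C@@H]2CN[C@H](C(=O)Nc3cccc(C(=O)O)c3)C2)[C@H](C)[C@@H]2[C@@H]([C@@H](C)O)C(=O)N12`: 0%
Compound 2, `C[C@@H](O)[C@H]1C(=O)N2C(C(=O)OCOC(=O)OC(C)(C)C)=C(S[C@@H]3CN[C@H](C(=O)Nc4cccc(C(=O)O)c4)C3)[C@H](C)[C@H]12`: 0%
Compound 3, `CCC(CC)C(=O)OCOC(=O)C1=C(S[C@@H]2CN[C@H](C(=O)Nc3cccc(C(=O)O)c3)C2)[C@H](C)[C@@H]2[C@@H]([C@@H](C)O)C(=O)N12`: 0%

Of the compounds shown here, three sharing one core have been tested in an ADME assay on a cell-free system (plasma, Rattus norvegicus) for metabolic stability, read by LC-MS, with a stated time of 60 min, at 37 degrees C, tested at 50 uM (on this read-out lower numbers stand for a less stable compound and higher numbers for a more stable compound), and each of them is fully gone by the end of the incubation. Compound 3 stands level with the other two: the steps of no change at the digits printed from compound 1 to compound 3 (within the scatter) and no change at the digits printed from compound 2 to compound 3 (within the scatter) are both flat, as is no change at the digits printed from compound 1 to compound 2 (within the scatter). The exchanged group in every case sits on the same carbonyl carbon of the side chain attached through oxygen next to a carbonyl group.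

Compound 4, `C[C@@H](O)[C@H]1C(=O)N2C(C(=O)OCOC(=O)OC3CCCCC3)=C(S[C@@H]3CN[C@H](C(=O)Nc4cccc(C(=O)O)c4)C3)[C@H](C)[C@H]12`, carries one further variation at that position: cyclohexyloxy in place of pentan-3-yl on a carbonyl carbon. For the measured compounds named here, the closest precedent is the step from compound 1 to compound 2, where an oxygen-linked group likewise replaced an alkyl group on that carbonyl carbon without any change in this assay. Since no exchange at this position has moved the read-out, the expected step is no change at the digits printed from compound 3 to compound 4 (within the scatter), that is, none beyond the scatter. Compound 4 is therefore estimated at 0%, with a range from 0% to 10%.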

Compound 4, percent of the compound remaining: 0%
For compound 4 middle estimate and measured number coincide at the digits printed, and the stated range covers the measured number.
By their numbers in this assay, from the lowest: compounds 1, 2, 3 and 4 (each within the scatter of the next).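

In this assay, for the compounds shown here, a ring appears at this position for the first time, and cyclohexyloxy, with its six-membered ring of carbon only, still gives no change at the digits printed from compound 3 to compound 4 (within the scatter), alongside no change at the digits printed from compound 2 to compound 4 (within the scatter) and no change at the digits printed from compound 1 to compound 4 (within the scatter). The carbonyl carbon therefore now carries a ring-bearing group, the open-chain isopropyl and pentan-3-yl groups, or tert-butoxy, all with the same reading at the bottom of the scale, where any difference in how quickly the compounds disappear before the final time point cannot be seen. No measured information is available to explain this result.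

Going by these compounds, it remains open whether an amine, a carboxylic acid or a longer straight chain on this carbonyl carbon would leave any compound remaining at the end of the incubation. Any such group would need a reading above the bottom of the scale before a difference at this position could be seen.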